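Cyano in place of methyl on the azole of compound 3

The source may report more compounds than this note shows. Statements on the series, on what has been measured and on what is new or still open speak of the compounds shown alone.

Measured so far:
compound 1, `Cc1cnn(C(=O)N2CCCCC2)c1`, 1100 nM
compound 2, `CN(CCN(C)C(=O)n1cc(C#N)cn1)Cc1cccc(OCc2ccccc2)c1`, 1100 nM
compound 3, `Cc1cnn(C(=O)N(C)CCN(C)C(c2ccc(OCc3ccccc3)cc2)c2ccc(OCc3ccccc3)cc2)c1`, > 1000000 nM

Values are from an assay on membranes from brain for binding affinity to Monoacylglycerol lipase ABHD6 (Mus musculus), read by fluorescence, with stated times of 1 h and 30 min; a higher number here means a weaker inhibitor, a lower number a stronger inhibitor. Compound 1 and compound 2 give the same value in this assay. As far as these compounds go, compound 3 gives only a limit of this assay, not a number, as in the limit of > 1000000 nM in this assay, at which 1 of the 3 values shown sits; where it would stand below that limit is unknown.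

Compound 4, `CN(CCN(C)C(c1ccc(OCc2ccccc2)cc1)c1ccc(OCc2ccccc2)cc1)C(=O)n1cc(C#N)cn1`, has not been measured. It differs from compound 3 in one place: cyano in place of methyl on an aromatic carbon. Among the compounds with values here, no measured pair in the set shows this change by itself, so no measured step tells its size. Compound 1 carries the methyl azole and compound 2 the cyano azole, each on a different remainder, and the two values show no difference beyond the scatter; this says nothing directly about the pair compound 3 and compound 4.

Compound 3 sits at the limit, so the estimate for compound 4 is expected to remain very weak: the step of an at least 2.0-fold lower number from compound 3 to compound 4 (0.30 log units; that floor lies within the scatter) is expected to be of unknown direction and within the range the limit allows. Compound 4 is estimated at 500000 nM, with a range from 50000 nM to 5000000 nM, and a sizeable chance that this assay again reports only a limit.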

Compound 4, half-maximal inhibitory concentration: > 1000000 nM
Compound 4 gave a limit, no number; the forecaster's own chance of this, stated with the estimate: 50%; at least 2.0-fold (0.30 log units) between middle value and limit.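

In this assay compound 4 gives > 1000000 nM as a limit and not a number. Compound 3 also stands at a limit, so no step can be read between compound 3 and compound 4: the limit of > 1000000 nM in this assay, at which 2 of the 4 values shown sit.

The compounds shown leave open the size and direction of any change from methyl to cyano on this aromatic carbon.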